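Azido in Place of Hydroxy on Compound 2

The compounds below may be only part of what the source reports. "The series", "measured", "known", "first", "only" and "open" are said of these compounds alone.

Cell-killing tests ask how little of a compound is needed to harm cells. Among the compounds with values here, in a functional assay on A549 cells (Homo sapiens) for cytotoxicity, read by resazurin assay, with a stated time of 48 h (on this read-out higher numbers stand for weaker inhibition and lower numbers for stronger inhibition), compound 2 `C=C(C)[C@@H]1CC=C(CN(OC)C2OC[C@@H](O)[C@H](O)[C@H]2O)CC1` gives 202000 nM, the higher of the two numbers measured so far and thus the weaker result. The other measured molecule, compound 1 `C=C(C)[C@@H]1CC=C(CN(OC)C2O[C@H](CO)[C@@H](N=[N+]=[N-])[C@H](O)[C@H]2O)CC1`, gives 4000 nM, a gap well beyond the scatter. Compound 3 `C=C(C)[C@@H]1CC=C(CN(OC)C2OC[C@@H](N=[N+]=[N-])[C@H](O)[C@H]2O)CC1`, not yet measured, is built from compound 2 by one change: azido in place of hydroxy on a saturated ring carbon. Within the data shown here, no pair of measured compounds differs in only one place, so the effect of this change has not been seen directly. Among the measured compounds shown here, the only hint is that compound 1, which also carries an azido group, sits at 4000 nM. That compound differs from compound 3 in more than the azido group, so the hint is weak. The expected change is a 10-fold lower number from compound 2 to compound 3 (1.00 log units; beyond the scatter), toward stronger inhibition and beyond the scatter. For compound 3 the estimated value is 20000 nM, with an expected range of 4000 nM to 100000 nM.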

Compound 3, half-maximal inhibitory concentration: 76000 nM
Compound 3: the middle estimate sits 3.8-fold (0.58 log units) below what was measured, and the stated range covers the measured number.
By their numbers in this assay, from the lowest: compound 1; then compound 3; then compound 2.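

In this assay the swap of hydroxy for azido on this saturated ring carbon has a real but modest effect on its own (a 2.7-fold lower number from compound 2 to compound 3 (0.42 log units; beyond the scatter)), so the azido group by itself moves the number toward stronger inhibition only a little. The other single change is much larger: with the azido group in place on both compounds, putting hydrogen in place of hydroxymethyl on a saturated ring carbon weakens the result (a 19-fold higher number from compound 1 to compound 3 (1.28 log units; beyond the scatter)), so in this small set the hydroxymethyl step outweighs the azido step. Nothing in the data shown explains why either change acts as it does.

As far as these compounds go, it remains open whether an amine or a methoxy group on the carbon that carries the azido group would move the number further than azido does, or whether a longer chain such as hydroxyethyl would do better than hydroxymethyl. Within the data shown here, it is also unclear whether the azido step would keep its size on a core that carries hydroxymethyl, since the only azido step seen so far lies on the core without it.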